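Ester in place of aminomethyl on the pendant ring

The source may report more compounds than this note shows. Statements on the series, on what has been measured and on what is new or still open speak of the compounds shown alone.

Measured so far in a functional assay on CEM-CCRF cells for antagonist activity at C-X-C chemokine receptor type 4 (Homo sapiens), read by calcium flux; a lower number here means a stronger inhibitor, a higher number a weaker inhibitor:
compound 1, `NCc1cc(C(F)(F)F)ccc1CN(Cc1nc2ccccc2[nH]1)C1CCCc2cccnc21`, gives 51 nM
compound 2, `NCc1ccc(CN(Cc2nc3ccccc3[nH]2)C2CCCc3cccnc32)c(CN)c1`, gives 10 nM
compound 3, `COCc1ccc(CN(Cc2nc3ccccc3[nH]2)C2CCCc3cccnc32)c(CN)c1`, gives 21 nM

Compound 2 holds the lowest number of the three. The nearest is compound 3, with a 2.1-fold higher number from compound 2 to compound 3 (0.32 log units; beyond the scatter); the furthest is compound 1, with a 5.1-fold lower number from compound 1 to compound 2 (0.71 log units; beyond the scatter) read in the other direction. Compound 3 itself stands at a 2.4-fold lower number from compound 1 to compound 3 (0.39 log units; beyond the scatter) from compound 1.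

Compound 4, `COC(=O)c1ccc(CN(Cc2nc3ccccc3[nH]2)C2CCCc3cccnc32)c(CN)c1`, is not yet measured. It differs from compound 2 by methoxycarbonyl in place of aminomethyl on an aromatic carbon. Within the data shown here, two measured steps bear on it. The step from compound 2 to compound 3 removes the amino of the aminomethyl and costs a 2.1-fold higher number from compound 2 to compound 3 (0.32 log units; beyond the scatter); the step from compound 1 to compound 2 shows that the aminomethyl group is worth a 5.1-fold lower number from compound 1 to compound 2 (0.71 log units; beyond the scatter) against trifluoromethyl. Compound 4 loses the donor entirely and carries a group without precedent in this set, so the expectation is a number higher than that of compound 2, most likely in the region of compound 3 or compound 1, since both lack the amino and both lie beyond the scatter from compound 2.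

The expected step is a 3.0-fold higher number from compound 2 to compound 4 (0.48 log units; beyond the scatter). Compound 4 is estimated at 30 nM, with a range from 12 nM to 80 nM.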

Compound 4, half-maximal inhibitory concentration: 39 nM
Beside the measured number, compound 4's estimate is 1.3-fold (0.11 log units) below it; measured number inside the range.
By their numbers in this assay, from the lowest: compound 2; then compounds 3, 4 and 1 (each within the scatter of the next, the first and the last beyond it).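

In this assay, methoxycarbonyl on this aromatic carbon gives (a 3.9-fold higher number from compound 2 to compound 4 (0.59 log units; beyond the scatter)), so this is a third group without the amino of the aminomethyl that ends beyond the scatter from compound 2. Compound 4 cannot be separated from either of the other two such compounds, with (a 1.9-fold higher number from compound 3 to compound 4 (0.27 log units; within the scatter)) and (a 1.3-fold lower number from compound 1 to compound 4 (0.12 log units; within the scatter)), even though methoxymethyl and trifluoromethyl lie beyond the scatter of each other (a 2.4-fold lower number from compound 1 to compound 3 (0.39 log units; beyond the scatter)); the ester therefore sits in the same band as both and does not add a distinct level to the series. No measurement on these compounds offers an explanation for the step away from compound 2.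

Across the compounds shown, the aminomethyl is the only group here with a nitrogen at this place, so one example carries the whole comparison, and whether the gain follows that nitrogen or that exact chain remains unsettled. An aminoethyl chain, a dimethylaminomethyl group, a primary amide or a carboxylic acid on the same carbon would test this, and would show whether the band shared by compounds 1, 3 and 4 is a floor for groups lacking an amine.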